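Aryl-piperazine propylamine series: cyano replaced by trifluoroethoxy

A few compounds are considered here, and "the series" means these few. Any claim that something is new, unique, unknown or untested is made for them only; others in the source may bear on it.

Measured so far in a functional assay for antagonist activity at Alpha-1A adrenergic receptor (Oryctolagus cuniculus); on this read-out lower numbers stand for tighter binding and higher numbers for weaker binding:
compound 1 `COc1ccccc1N1CCN(CCCNc2nc(C)cc(C)c2C(N)=O)CC1` gives 10 nM
compound 2 `COc1ccccc1N1CCN(CCCSc2ccccc2C(=O)N(C)C)CC1` gives 2 nM
compound 3 `CN(C)C(=O)c1cccnc1NCCCN1CCN(c2ccccc2C#N)CC1` gives 2 nM

Compound 3 stands level with compound 2 at the digits shown; the two together hold the lowest numbers of the three, and the gap between them lies within the scatter, so no order between them can be read. The furthest number from compound 3 is that of compound 1, which sits higher by a margin beyond the scatter. For the measured compounds named here, no two measured compounds differ in a single place, so the size of any one structural change in this assay is not yet known.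

Compound 4 `CN(C)C(=O)c1cccnc1NCCCN1CCN(c2ccccc2OCC(F)(F)F)CC1` differs from compound 3 by 2,2,2-trifluoroethoxy in place of cyano on an aromatic carbon. Going by the values given here, without a measured step for a change of this kind, the expectation rests on the spread of the three known numbers: compounds 1 and 2, which lack the cyano group, stay within a narrow band, compound 1 giving 10 nM and compound 2 giving 2 nM. The step from compound 3 to compound 4 is therefore expected to be small, a 1.5-fold higher number from compound 3 to compound 4 (0.18 log units; within the scatter), if anything toward a slightly higher number, and possibly none beyond the scatter. Compound 4 is estimated at 3 nM, with a range from 0.8 nM to 12 nM.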

Compound 4, dissociation constant: 0.1 nM
The estimate for compound 4 lay 30-fold (1.48 log units) above the measured number; the measured number lies below the stated range.
By their numbers in this assay, from the lowest: compound 4; then compounds 2 and 3 (each within the scatter of the next); then compound 1.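

In this assay, for the compounds shown here, the place on an aromatic carbon ortho to a large group proves responsive: 2,2,2-trifluoroethoxy in place of cyano gives a 20-fold lower number from compound 3 to compound 4 (1.30 log units; beyond the scatter) as the first single-place step, and it is large. The earlier compounds shown here gave no size for any one change, so their narrow spread said little about how far a single substituent could move the number; here, one exchange with the rest of compound 3 unchanged moves it beyond the scatter. No measurement at hand bears on why the step has this size.

Still open, going by these compounds, is which part of the 2,2,2-trifluoroethoxy group carries the step, and a plain ethoxy group or a 3,3,3-trifluoropropoxy group at the same place on the core of compound 3 would begin to separate the oxygen link, the fluorines and the chain length. Also open, on these data alone, is whether a single fluorine, a trifluoromethyl group or an amine at this place would keep the low number, and whether the step carries over to the cores of compound 1 and compound 2.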